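The source may report more compounds than this note shows. Statements on the series, on what has been measured and on what is new or still open speak of the compounds shown alone.

In a functional assay on MX1 cells (Homo sapiens) for inhibition, read by MTT assay, with a stated time of 120 h (on this read-out lower numbers stand for stronger inhibition and higher numbers for weaker inhibition), compound 1 (`C/C(=C\c1ccc(NC(=O)Nc2ccc(Cl)c(C(F)(F)F)c2)cc1)C(=O)NC(C)c1ccccc1`) gives > 50000 nM, a limit of the assay and not a number. Compound 2 (`CNC(=O)/C(C)=C/c1ccc(NC(=O)Nc2ccc(Cl)c(C(F)(F)F)c2)cc1`) gives > 50000 nM, also a limit. Compound 3 (`C/C(=C\C(=O)N1CC(C)OC(C)C1)c1ccc(NC(=O)Nc2ccc(Cl)c(C(F)(F)F)c2)cc1`) gives > 50000 nM, again a limit. Compound 2 therefore has no number of its own and stands with the other two, as the limit of > 50000 nM in this assay, at which 3 of the 3 values shown sit, records. Among the measured compounds shown here, the only measured step is a step that the two limits leave unreadable from compound 1 to compound 2, so it offers no size to carry forward.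

Compound 4 (`CNC(=O)C#Cc1ccc(NC(=O)Nc2ccc(Cl)c(C(F)(F)F)c2)cc1`) replaces 2-(methylcarbamoyl)prop-1-en-1-yl with 2-(methylcarbamoyl)ethynyl on an aromatic carbon, para to a large group: 2-(methylcarbamoyl)ethynyl in place of 2-(methylcarbamoyl)prop-1-en-1-yl on an aromatic carbon. For the measured compounds named here, no measured step covers this change, so neither its size nor its direction can be read from the series. With compound 2 at > 50000 nM, the expectation in this assay is no clear step beyond the scatter, and a further limit is the likeliest report. The expected step is a number no higher from compound 2 to compound 4 (the limit leaves the size open). For compound 4 the estimate is 50000 nM, with an expected range from 15000 nM to 90000 nM.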

Compound 4, half-maximal inhibitory concentration: 26400 nM
Beside the measured number, compound 4's estimate is 1.9-fold (0.28 log units) above it; the range from low to high includes it.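

At this position, on an aromatic carbon para to a large group, 2-(methylcarbamoyl)ethynyl in place of 2-(methylcarbamoyl)prop-1-en-1-yl gives a readable result in this assay, and compound 4 is the only compound shown with a number, 26400 nM. The change gives an at least 1.8-fold lower number from compound 2 to compound 4 (0.27 log units; that floor lies within the scatter). On these data alone, the full size of that step stays open because compound 2 has a limit and not a number: the limit of > 50000 nM in this assay, at which 3 of the 4 values shown sit.

Whether the step truly exceeds the scatter cannot be told from these compounds. Also open, as far as these compounds go, is whether the 2-(methylcarbamoyl)ethynyl group tolerates other ends, such as a carboxylic acid or an amine in place of the methylcarbamoyl end, or a longer chain on the amide nitrogen, and how far such changes would move the number in this assay.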